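Replacing the chloro of compound 1 with a sulfur-linked ring

The compounds below may be only part of what the source reports. "The series", "measured", "known", "first", "only" and "open" are said of these compounds alone.

Compound 1 `Cn1c(-c2ccc(NC(=O)CCl)cc2)nc(-c2ccccc2)c1-c1ccccc1` is one of three analogues sharing a common core and differing only in the group attached to the saturated chain carbon bound to the carbonyl carbon. In a functional assay on MCF7 cells (Homo sapiens) for cytotoxicity, read by MTT assay, with a stated time of 24 h, tested at 0.64 ug/mL (a higher number here means a stronger effect of the compound at the concentration tested, a lower number a weaker effect), compound 1 gives 3.4%, the second highest of the three numbers. Compound 2 `Cc1ccc2oc(SCC(=O)Nc3ccc(-c4nc(-c5ccccc5)c(-c5ccccc5)n4C)cc3)nc2c1` gives 1.1%, so that the step of a number 2.3 percentage points lower from compound 1 to compound 2 (within the scatter) stays within the scatter. Compound 3 `Cc1nnc(SCC(=O)Nc2ccc(-c3nc(-c4ccccc4)c(-c4ccccc4)n3C)cc2)s1` gives 35.1%, and the step of a number 31.7 percentage points higher from compound 1 to compound 3 (beyond the scatter) is large. Compound 4 `Cn1c(-c2ccc(NC(=O)CSC3=NCCS3)cc2)nc(-c2ccccc2)c1-c1ccccc1` carries a group of 6 heavy atoms (3 carbon, 1 nitrogen, 2 sulfur; one five-membered non-aromatic ring with 2 hetero atoms) in place of one chlorine atom, on a saturated chain carbon bound to a carbonyl carbon. Both measured steps from compound 1 also exchange the chloro for a sulfur-linked heterocycle, yet one moved nothing and the other moved far, so the direction for a new ring of this kind is open. The entering group of compound 4 is smaller than that of compound 2 and not aromatic, unlike either. The author therefore expects a modest rise, estimated as a number 8.6 percentage points higher from compound 1 to compound 4 (within the scatter), and estimates for compound 4 a value of 12% within the range 0% to 40%.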

Compound 4, a percentage reported as activity, at one concentration (the size of the read-out at that concentration, not a potency): 10.3%
Beside the measured number, compound 4's estimate is 1.7 percentage points above it; the range from low to high includes it.
By their numbers in this assay, from the lowest: compounds 2, 1 and 4 (each within the scatter of the next); then compound 3.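

In this assay, the new non-aromatic five-membered ring on the sulfur gives a number 6.9 percentage points higher from compound 1 to compound 4 (within the scatter), and, set against the 5-methyl-1,3-benzoxazol-2-yl group, it gives a number 9.2 percentage points higher from compound 2 to compound 4 (within the scatter). Set against the 5-methyl-1,3,4-thiadiazol-2-yl group, the same ring gives a number 24.8 percentage points lower from compound 3 to compound 4 (beyond the scatter), so a sulfur-linked ring alone does not bring the large rise at this position, and neither does an aromatic ring, since the 5-methyl-1,3-benzoxazol-2-yl group goes against that reading. No measurement at hand explains why the 5-methyl-1,3,4-thiadiazol-2-yl group stands apart. The compounds shown leave open whether a 1,3,4-thiadiazol-2-yl ring without its methyl group would keep that number. They also leave open what a morpholine amine or a carboxylic acid would give on the saturated chain carbon bound to a carbonyl carbon.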